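The compounds below may be only part of what the source reports. "The series", "measured", "known", "first", "only" and "open" are said of these compounds alone.

Measured in a functional assay on KYSE-450 cells (Homo sapiens) for inhibition, read by CCK-8 assay, with a stated time of 48 h; on this read-out higher numbers stand for weaker inhibition and lower numbers for stronger inhibition:
compound 1 `COc1ccc(CN(C(=O)CSC(=S)N2CCN(C(=O)OC(C)(C)C)CC2)c2cc(OC)c(OC)c(OC)c2)cc1`: 250 nM
compound 2 `COc1ccc(CN(C(=O)CN2CCN(C(=O)OC(C)(C)C)CC2)c2cc(OC)c(OC)c(OC)c2)cc1`: 8170 nM
compound 3 `COc1ccc(CN(C(=O)CSC(=S)N2CCN(C(=O)OC(C)(C)C)CC2)c2ccc(Cl)cc2)cc1`: > 20000 nM

The entry for compound 3, > 20000 nM, is a limit and not a number, and it is the sole entry of its kind: the limit of > 20000 nM in this assay, at which 1 of the 3 values shown sits. Compound 4 `COc1ccc(CN(C(=O)CSC(=S)N2CCN(C(=O)OC(C)(C)C)CC2)c2ccccc2)cc1` has hydrogen in place of chloro on an aromatic carbon, para to a large group, a change from 4-chlorophenyl to phenyl (hydrogen in place of chloro on an aromatic carbon). For the measured compounds named here, the only measured step that bears on this is an at least 80-fold higher number from compound 1 to compound 3 (1.90 log units; beyond the scatter), where 4-chlorophenyl replaced 3,4,5-trimethoxyphenyl on an amide-type nitrogen. Going by the values given here, compound 4 also lacks 3,4,5-trimethoxyphenyl, and no measured step removes chloro alone, so no change beyond the scatter is expected. The expected step is a number no higher from compound 3 to compound 4 (the limit leaves the size open). For compound 4 the estimated value in this assay is 20000 nM, with an expected range from 7000 nM to 50000 nM.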

Compound 4, half-maximal inhibitory concentration: > 20000 nM
Compound 4 gave a limit, no number (the forecaster's own chance of this, stated with the estimate: 65%); the middle value sits exactly at the limit.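

In this assay the entry for compound 4, > 20000 nM, is a limit and not a number. Plain phenyl in place of 3,4,5-trimethoxyphenyl gives an at least 80-fold higher number from compound 1 to compound 4 (1.90 log units; beyond the scatter), so the large loss seen with 4-chlorophenyl does not depend on the chloro. The step between compound 3 and compound 4 cannot be read, as both stand at the same limit: the limit of > 20000 nM in this assay, at which 2 of the 4 values shown sit.

The compounds shown leave open how many of the three methoxy groups are needed. They also leave open whether a phenyl carrying a single methoxy group or an amino group would restore any of the activity.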